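An (ethoxycarbonyl)carbonyl group on compound 2

This account rests on a few compounds, and the source may have more. Where it says the series, first, only, none or still open, it means among the compounds named here.

In a functional assay on the whole organism (strain Sprague-Dawley) for inhibition, with Rattus norvegicus as the target, with a stated time of 10 min (on this read-out higher numbers stand for an effect only at larger amounts of compound and lower numbers for an effect already at smaller amounts), compound 1 `CCOC(=O)c1ccc(OCC)c(-c2ncc(C(=O)OCC)c(=O)[nH]2)c1` gives 1 mg/kg, and compound 2 `CCOC(=O)c1cnc(-c2cc(N)ccc2OCC)[nH]c1=O` gives 0.5 mg/kg. For the measured compounds named here, these are the only two numbers so far, and they lie within the scatter of each other, so compound 2 cannot be separated from compound 1. Going by the values given here, the one measured step, amino in place of ethoxycarbonyl on an aromatic carbon, is a 2.0-fold lower number from compound 1 to compound 2 (0.30 log units; within the scatter). Compound 3 `CCOC(=O)C(=O)Nc1ccc(OCC)c(-c2ncc(C(=O)OCC)c(=O)[nH]2)c1` carries (ethoxycarbonyl)carbonyl in place of hydrogen on a nitrogen on an aromatic ring. Among the compounds with values here, no measured step makes this exact change, so the step above is the only guide, and it is thin evidence. No shift beyond the scatter is therefore expected in this assay, though the uncertainty is wide. The estimated step is a 1.3-fold lower number from compound 2 to compound 3 (0.10 log units; within the scatter). For compound 3 the estimated value is 0.4 mg/kg, with an expected range of 0.08 mg/kg to 2 mg/kg.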

Compound 3, dose for 50% inhibition: 5 mg/kg
Estimate against measurement, compound 3: 13-fold (1.10 log units) below; the measured number lies above the stated range.
By their numbers in this assay, from the lowest: compounds 2 and 1 (each within the scatter of the next); then compound 3.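

In this assay, for the compounds shown here, the nitrogen on an aromatic ring does not take (ethoxycarbonyl)carbonyl in place of hydrogen without cost: the change gives a 10-fold higher number from compound 2 to compound 3 (1.00 log units; beyond the scatter) and is the first step to lie beyond the scatter. Measured against the ethoxycarbonyl group on the aromatic carbon, ((ethoxycarbonyl)carbonyl)amino gives a 5.0-fold higher number from compound 1 to compound 3 (0.70 log units; beyond the scatter) in the same direction, so this place responds to the group it carries, although amino and ethoxycarbonyl could not be separated there. Nothing available bears on why the number rises.

Open, from the compounds shown here alone, is which part of the (ethoxycarbonyl)carbonyl group goes with this step. An acetyl group on the same nitrogen, or a carboxylic acid in place of the ethyl ester of that group, would help separate the parts.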